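Swapping a Methylphenyl for a Formylphenyl on the Core

This account rests on a few compounds, and the source may have more. Where it says the series, first, only, none or still open, it means among the compounds named here.

Measured so far:
compound 1, `O=Cc1ccc(-c2cn3ccnc3c(-c3ccc4ncn(C5CCCCC5)c4c3)n2)cc1`, giving 20.7%
compound 2, `Cc1cccc(-c2cn3ccnc3c(-c3ccc4ncn(Cc5ccccc5)c4c3)n2)c1`, giving 4.72%

Both values come from a functional assay on SN12C cells (Homo sapiens) for inhibition, read by sulforhodamine B assay, with a stated time of 48 h, tested at 10 uM; on this read-out higher numbers stand for more inhibition at the one concentration tested (going by the name of the read-out) and lower numbers for less inhibition. Compound 2 stands lowest of the two numbers; its nearest neighbour, compound 1, lies higher by a margin beyond the usual scatter of repeated measurements. Among the compounds with values here, compound 1 and compound 2 differ from each other in two places at once, so no single step between them can be read off; only their two values can be set side by side.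

Compound 3, `O=Cc1ccc(-c2cn3ccnc3c(-c3ccc4ncn(Cc5ccccc5)c4c3)n2)cc1`, has not yet been measured in this assay. It differs from compound 2 in one place: 4-formylphenyl in place of 3-methylphenyl on an aromatic carbon. The 4-formylphenyl that enters is the very group carried by compound 1, while the remainder of compound 3 matches compound 2.

The expected step of a number 7.3 percentage points higher from compound 2 to compound 3 (within the scatter) is upward and of modest size, roughly at the edge of the usual scatter, because compound 1 carrying the same 4-formylphenyl gives 20.7% in this assay. Compound 3 is therefore expected to give about 12%, estimated to fall between 0% and 28%.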

Compound 3, a percentage reported as inhibition, at one concentration (the size of the read-out at that concentration, not a potency): 20.7%
For compound 3 the middle estimate is 8.7 percentage points below the measured one; the range from low to high includes it.
By their numbers in this assay, from the lowest: compound 2; then compounds 1 and 3 (each within the scatter of the next).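

In this assay, 4-formylphenyl in place of 3-methylphenyl on the aromatic carbon of the shared core gives a number 16 percentage points higher from compound 2 to compound 3 (beyond the scatter) with the benzyl group held constant, so the read-out responds to the group at this position, which the two earlier compounds, differing in two places at once, could not show. The other new step isolates the group on the aromatic nitrogen: with 4-formylphenyl held constant, benzyl in place of cyclohexyl gives no change at the digits printed from compound 1 to compound 3 (within the scatter) and so leaves the read-out within the scatter. Nothing available here explains the rise at this position.

From the compounds shown here alone, because the swap changes both the substituent and where it sits on the phenyl ring, it remains open whether the rise belongs to the formyl group or to its placement, and a 4-methylphenyl or a 3-formylphenyl would separate the two. Also open, going by these compounds, are how a phenyl ring carrying an amine or a carboxylic acid would read at this position, and whether benzyl and cyclohexyl still match when 3-methylphenyl sits on the core.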